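The source may hold more compounds than are shown below. What is called first, only, known or untested is meant among the compounds shown, and "the series" means these compounds.

For the measured compounds named here, in an ADME assay on MT4 cells (Homo sapiens) for cytotoxicity, read by MTT assay (a higher number here means that more compound is tolerated, a lower number that less compound is tolerated), compound 1 (`Cc1cc(C)cc(S(=O)(=O)c2c(C(=O)Nc3ccc(CO)cc3)[nH]c3ccc(Cl)cc23)c1`) gives 39600 nM and compound 2 (`COc1cc(CNC(=O)c2[nH]c3ccc(Cl)cc3c2S(=O)(=O)c2cc(C)cc(C)c2)ccc1O`) gives 28700 nM as its reading, so compound 2 stands within the scatter of the only other compound measured. Going by the values given here, the one measured step (a 1.4-fold lower number from compound 1 to compound 2 (0.14 log units; within the scatter)) is also the only guide to what follows. Compound 3 (`Cc1cc(C)cc(S(=O)(=O)c2c(C(=O)NCC(=O)NCc3ccccc3O)[nH]c3ccc(Cl)cc23)c1`) has not yet been measured. Its difference from compound 2 is (2-hydroxybenzyl)carbamoyl in place of 4-hydroxy-3-methoxyphenyl on a saturated chain carbon bound to an amide-type nitrogen on a saturated chain carbon bound to an amide-type nitrogen. Among the compounds with values here, the data hold no direct precedent for this exchange, and the single step seen so far stays within the scatter. No step beyond the scatter is therefore expected in this assay and no direction can be favoured. The estimated change is a 1.0-fold higher number from compound 2 to compound 3 (0.02 log units; within the scatter) at most a small one. Compound 3 is expected at 30000 nM with an estimated range from 12000 nM to 70000 nM for this reading.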

Compound 3, half-maximal cytotoxic concentration: > 47300 nM
Compound 3 was reported as a limit (the forecaster's own chance of this, stated with the estimate: 15%); middle value at least 1.5-fold (0.19 log units) away from the limit.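

In this assay compound 3 gives > 47300 nM, which is a limit of the assay and not a number. The exchange on a saturated chain carbon bound to an amide-type nitrogen shows an at least 1.6-fold higher number from compound 2 to compound 3 (0.21 log units; that floor lies within the scatter), while the wider change on the amide-type nitrogen shows an at least 1.1-fold higher number from compound 1 to compound 3 (0.07 log units; that floor lies within the scatter). Neither step is shown to pass the scatter, but this position accepts (2-hydroxybenzyl)carbamoyl with no sign that less compound is tolerated, which the earlier pair could not show.

From the compounds shown here alone, the true reading of compound 3, and so the real size of both steps, cannot be told from a limit: the limit of > 47300 nM in this assay, at which 1 of the 3 values shown sits. Also open is whether an amine or a carboxylic acid in place of (2-hydroxybenzyl)carbamoyl at this position would leave the number as high.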